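This account rests on a few compounds, and the source may have more. Where it says the series, first, only, none or still open, it means among the compounds named here.

Measured so far:
- Compound 1 `Cc1nc(C(c2ccc(-c3ccc4cccc(F)c4c3)[nH]c2=O)C(C)C)[nH]c1C`: 0.268 h
- Compound 2 `CC(C)C(c1ncc[nH]1)c1ccc(-c2ccc3cccc(F)c3c2)[nH]c1=O`: < 0.0667 h (a limit)

Both compounds were tested in an ADME assay on microsomes from liver (Homo sapiens) for metabolic stability; on this read-out higher numbers stand for a longer-lived compound and lower numbers for a shorter-lived compound. Compound 2 gives < 0.0667 h, which is a limit of the assay and not a number.

Compound 3 `CC(C)C(Cc1nnn[nH]1)c1ccc(-c2ccc3cccc(F)c3c2)[nH]c1=O` carries (1H-tetrazol-5-yl)methyl in place of 1H-imidazol-2-yl, on the saturated chain carbon bound to an aromatic carbon and a saturated chain carbon: (1H-tetrazol-5-yl)methyl in place of 1H-imidazol-2-yl on a saturated chain carbon bound to an aromatic carbon and a saturated chain carbon.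

Going by the values given here, one measured step bears on this, and it lies at the same place. Replacing 4,5-dimethyl-1H-imidazol-2-yl with 1H-imidazol-2-yl gave an at least 4.0-fold lower number from compound 1 to compound 2 (0.60 log units; beyond the scatter). Among the compounds with values here, this shows that a change here can move the half-life beyond the scatter, but no measured compound yet carries a tetrazole, so it is only a loose guide. An upward move of similar size is therefore expected, although the assay could again report only a limit.

The expected change is an at least 2.9-fold higher number from compound 2 to compound 3 (0.47 log units; beyond the scatter).

For compound 3, the estimated half-life is 0.2 h, with an expected range of 0.07 h to 0.8 h.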

Compound 3, half-life: > 3 h
Compound 3: a limit, no number (the forecaster's own chance of this, stated with the estimate: 20%); middle value at least 15-fold (1.17 log units) from the limit.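

Going by these compounds alone, until now this position, the saturated chain carbon bound to an aromatic carbon and a saturated chain carbon, had carried only two imidazole groups, and the one measured step there was downward. Placing (1H-tetrazol-5-yl)methyl there instead of 1H-imidazol-2-yl gives an at least 44-fold higher number from compound 2 to compound 3 (1.65 log units; beyond the scatter), while placing it there instead of 4,5-dimethyl-1H-imidazol-2-yl gives an at least 11-fold higher number from compound 1 to compound 3 (1.04 log units; beyond the scatter), so in this assay the position can also carry a large gain, and this gain holds against both imidazole groups. Compound 3 gives > 3 h, which is a limit of the assay and not a number, so the full size of both steps stays unknown: the limit of > 3 h in this assay, at which 1 of the 3 values shown sits.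

The change replaces the ring and adds a methyl link in a single step, so the compounds shown cannot tell which of the two accounts for the gain. 1H-tetrazol-5-yl bound directly to the chain carbon and (1H-imidazol-2-yl)methyl would separate these two parts, while a carboxylic acid or a longer chain ending in the same tetrazole ring would show how far the gain extends beyond this one group.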